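The compounds below may be only part of what the source reports. "The series", "measured", "known", "first", "only" and "open" are said of these compounds alone.

Compound 1 `COc1cc(-c2nnc(SC)n2-c2ccc(N(C)C)cc2)cc(OC)c1OC` in a functional assay on HCT-116 cells (Homo sapiens) for inhibition, read by MTT assay, with a stated time of 48 h (on this read-out higher numbers stand for weaker inhibition and lower numbers for stronger inhibition), gives > 60000 nM, which is a limit of the assay.
Compound 2 `COc1cc(-c2nnc(SCC(=O)c3ccccc3)n2-c2ccc(N(C)C)cc2)cc(OC)c1OC` in this assay gives 42500 nM.
Compound 3 `COc1cc(-c2nnc(SCC(=O)c3ccc(F)cc3)n2-c2ccc(N(C)C)cc2)cc(OC)c1OC` in this assay gives 31100 nM.

Among the measured compounds shown here, compound 3 carries one of only two numbers; the other is separated by a 1.4-fold lower number from compound 2 to compound 3 (0.14 log units; within the scatter), so the two are not distinguished. The remaining compound sits at the limit (the limit of > 60000 nM in this assay, at which 1 of the 3 values shown sits).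

Compound 4 `COc1cc(-c2nnc(SCC(=O)c3ccc4ccccc4c3)n2-c2ccc(N(C)C)cc2)cc(OC)c1OC` differs from compound 3 in one place: naphthalen-2-yl in place of 4-fluorophenyl on a carbonyl carbon. For the measured compounds named here, the steps that bear on this are the introduction of benzoyl, an at least 1.4-fold lower number from compound 1 to compound 2 (0.14 log units; that floor lies within the scatter), of (4-fluorophenyl)carbonyl, an at least 1.9-fold lower number from compound 1 to compound 3 (0.28 log units; that floor lies within the scatter), and the fluoro for hydrogen exchange, a 1.4-fold lower number from compound 2 to compound 3 (0.14 log units; within the scatter). None of these floors or steps exceeds the scatter, so the exchange of the ring on the carbonyl carbon is expected to move the number little, if anything modestly downward.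

For compound 4 the expected value is 25000 nM, with a range of 10000 nM to 60000 nM. The step this implies, a 1.2-fold lower number from compound 3 to compound 4 (0.09 log units; within the scatter), is expected to lie within the scatter.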

Compound 4, half-maximal inhibitory concentration: 54500 nM
Beside the measured number, compound 4's estimate is 2.2-fold (0.34 log units) below it, and the stated range covers the measured number.
By their numbers in this assay, from the lowest: compounds 3, 2 and 4 (each within the scatter of the next). At a limit, above all of these: compound 1.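

In this assay, replacing the single aromatic ring on the carbonyl carbon with naphthalen-2-yl gives a 1.8-fold higher number from compound 3 to compound 4 (0.24 log units; within the scatter) and a 1.3-fold higher number from compound 2 to compound 4 (0.11 log units; within the scatter). Even this larger, two-ring group therefore leaves compounds 2, 3 and 4 undistinguished at this position. Compound 1 is a limit of the assay, not a number: the limit of > 60000 nM in this assay, at which 1 of the 4 values shown sits. The remaining step is an at least 1.1-fold lower number from compound 1 to compound 4 (0.04 log units; that floor lies within the scatter), which is only a floor.

Still open, on these data alone, is whether an amine or a carboxylic acid in place of the ring on the carbonyl carbon would move the number beyond the scatter.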